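Toward a nitrophenyl analogue in the thiosemicarbazone series

A few compounds are considered here, and "the series" means these few. Any claim that something is new, unique, unknown or untested is made for them only; others in the source may bear on it.

Compound 2 `CC1=CC[C@@H]([C@@](C)(O)CCCC(C)(C)NC(=S)N/N=C\c2ccc(O)cc2)CC1` gives 21200 nM in a functional assay on MCF7 cells (Homo sapiens) for cytotoxicity, read by sulforhodamine B assay; on this read-out higher numbers stand for weaker inhibition of growth and lower numbers for stronger inhibition of growth. That is the lowest of the two numbers recorded so far, yet the nearest neighbour sits within the scatter: compound 1 `CC1=CC[C@@H]([C@@](C)(O)CCCC(C)(C)NC(=S)N/N=C\c2ccccc2)CC1` gives 28700 nM in this assay, and the step is a 1.4-fold lower number from compound 1 to compound 2 (0.13 log units; within the scatter). So the two measured compounds cannot be told apart on this read-out.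

Compound 3 `CC1=CC[C@@H]([C@@](C)(O)CCCC(C)(C)NC(=S)N/N=C\c2ccccc2[N+](=O)[O-])CC1` has not been measured. It differs from compound 2 in one place: 2-nitrophenyl in place of 4-hydroxyphenyl on a carbon with a double bond to nitrogen. Going by the values given here, the only measured step that bears on it is a 1.4-fold lower number from compound 1 to compound 2 (0.13 log units; within the scatter), which shows that replacing a hydrogen on that aromatic ring by hydroxy moved the number only within the scatter. Among the compounds with values here, no measured step covers a nitro group, and the data give nothing on the 2-position of the ring. Within the data shown here, with the one relevant step this small, the expected step from compound 2 to compound 3 is a 1.2-fold higher number from compound 2 to compound 3 (0.07 log units; within the scatter), none beyond the scatter in either direction. Compound 3 is therefore estimated at 25000 nM, with a range from 9000 nM to 70000 nM, the range kept wide since the change is not directly precedented.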

Compound 3, concentration for total growth inhibition: > 100000 nM
Compound 3 was reported as a limit (the forecaster's own chance of this, stated with the estimate: 15%); middle value at least 4.0-fold (0.60 log units) away from the limit.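

Nitro is the first group shown to move the number beyond the scatter at this place, on a carbon with a double bond to nitrogen. In this assay, the change from 4-hydroxyphenyl to 2-nitrophenyl gives an at least 4.7-fold higher number from compound 2 to compound 3 (0.67 log units; beyond the scatter), and placing nitro on the unsubstituted ring gives an at least 3.4-fold higher number from compound 1 to compound 3 (0.54 log units; beyond the scatter), whereas the hydroxy step gave only a 1.4-fold lower number from compound 1 to compound 2 (0.13 log units; within the scatter). So the aromatic ring is not indifferent to what it carries, and with the nitro group the change is toward weaker inhibition of growth, not merely scatter around the earlier numbers. Compound 3 is recorded only as a limit, not as a number: the limit of > 100000 nM in this assay, at which 1 of the 3 values shown sits.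

As far as these compounds go, the true size of the shift therefore stays unknown, and so does whether it belongs to the nitro group itself or to its being in the 2-nitrophenyl arrangement rather than elsewhere on the ring. Also open, from the compounds shown here alone, is how an amine or a methoxy group on the same ring would read in this assay, which would show whether nitro stands alone in moving the number this way.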